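Chloro to bromo on the spiro-pyrazolone aryl ring

The source may report more compounds than this note shows. Statements on the series, on what has been measured and on what is new or still open speak of the compounds shown alone.

Compound 1 `CC1=NN(c2ccc(Br)cc2)C(=O)C12C=CC(=O)C=C2c1ccccc1` — in a functional assay on A549 cells (Homo sapiens) for antiproliferative activity, read by CCK-8 assay, with a stated time of 72 h (a higher number here means a weaker inhibitor, a lower number a stronger inhibitor), compound 1 gives only the limit > 100000 nM.
Compound 2 `CC1=NN(c2ccc(Cl)cc2)C(=O)C12C=CC(=O)C=C2c1cccc(C)c1` — in this assay compound 2 gives 38400 nM.
Compound 3 `CC1=NN(c2ccc(Br)cc2)C(=O)C12C=CC(=O)C=C2c1cccc(C)c1` — not yet measured.

Among the compounds with values here, compound 2 holds the only numeric value shown; the other entry, that of compound 1, is a limit of > 100000 nM in this assay, at which 1 of the 2 values shown sits, and not a number, so no step between compound 1 and compound 2 can be sized, and they differ in two places besides.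

Compound 3 differs from compound 2 in one place: bromo in place of chloro on an aromatic carbon. Within the data shown here, no measured pair in this set shows the effect of that exchange, so there is no step to lean on. The counted difference is a single halogen for another on the same aromatic carbon, with nothing else changing, and the expectation is a step in this assay no larger than the usual scatter, in no fixed direction.

For compound 3 the estimated value in this assay is therefore 45000 nM, with a range from 18000 nM to 110000 nM, which is an expected step of a 1.2-fold higher number from compound 2 to compound 3 (0.07 log units; within the scatter) from compound 2.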

Compound 3, half-maximal inhibitory concentration: 45400 nM
Beside the measured number, compound 3's estimate is 1.0-fold (0.00 log units) below it; the measured number falls inside the stated range.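

In this assay, bromo in place of chloro on the aromatic carbon para to a large group gives a 1.2-fold higher number from compound 2 to compound 3 (0.07 log units; within the scatter), the first size shown for this exchange, and it is within the scatter, so the 4-chlorophenyl and 4-bromophenyl forms cannot be told apart at this position when the methyl is present. With bromo held fixed, methyl in place of hydrogen on an aromatic carbon gives an at least 2.2-fold lower number from compound 1 to compound 3 (0.34 log units; beyond the scatter), which is beyond the scatter but fixes only the smallest size the step can have, so among the two single changes read here, only the methyl exchange registers. Compound 1 gives a limit and not a number: the limit of > 100000 nM in this assay, at which 1 of the 3 values shown sits.

The compounds shown leave open whether an amine, a carboxylic acid or a longer chain in place of the halogen on this carbon would change the number in this assay. They also leave open whether the exchange of chloro for bromo reads the same without the methyl, and whether a methoxy or an ethyl group in place of that methyl would extend its step.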